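Replacing the aromatic ester of compound 3 with a nitrophenyl analogue

The source may report more compounds than this note shows. Statements on the series, on what has been measured and on what is new or still open speak of the compounds shown alone.

Measured compounds in a functional assay on SK-BR-3 cells (Homo sapiens) for antiproliferative activity, read by MTT assay, with a stated time of 72 h; a lower number here means a stronger inhibitor, a higher number a weaker inhibitor:
compound 1 `C/C=C1/[C@H](O[C@@H]2O[C@H](CO)[C@@H](O)[C@H](O)[C@H]2O)OC=C(C(=O)OC)[C@H]1CC(=O)OCCCCCCCCCCCCCCC` — 1600 nM
compound 2 `C#CCOC(=O)C[C@@H]1C(C(=O)OC)=CO[C@@H](O[C@@H]2O[C@H](COC(C)=O)[C@@H](OC(C)=O)[C@H](OC(C)=O)[C@H]2OC(C)=O)/C1=C/C` — > 15000 nM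
compound 3 `C/C=C1/[C@H](O[C@@H]2O[C@H](CO)[C@@H](O)[C@H](O)[C@H]2O)OC=C(C(=O)OC)[C@H]1CC(=O)OCCCc1ccc(OC)c(OC)c1` — > 20000 nM

Of the three, only compound 1 gives a number, 1600 nM. For compound 2 the assay reports only a limit, > 15000 nM. Going by these compounds, for compound 3 the assay likewise reports only a limit, > 20000 nM, so compound 3 stands at the weak end of what has been measured and its true number is unknown. Within the data shown here, the single step between two measured compounds, an at least 12-fold higher number from compound 1 to compound 3 (1.09 log units; beyond the scatter), is large and shows that exchanging the dodecyl chain for an aromatic ester drives the value to the limit (the limit of > 20000 nM in this assay, at which 1 of the 3 values shown sits).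

Compound 4 `C/C=C1/[C@H](O[C@@H]2O[C@H](CO)[C@@H](O)[C@H](O)[C@H]2O)OC=C(C(=O)OC)[C@H]1CC(=O)OCCc1ccc([N+](=O)[O-])cc1` has not yet been measured. It differs from compound 3 as follows: 4-nitrophenyl in place of 3,4-dimethoxybenzyl on a saturated chain carbon, two bonds along the chain from an oxygen next to a carbonyl group. Among the measured compounds shown here, no measured step covers this particular exchange. What the measured steps do say is that the aromatic ester of compound 3 is already at a limit, and compound 2, another ester lacking the dodecyl chain, sits at the limit (the limit of > 15000 nM in this assay, at which 1 of the 3 values shown sits). Compound 4 keeps an aromatic ester and is therefore expected to stay near the limit, with an estimated step of a number no higher from compound 3 to compound 4 (the limit leaves the size open) that would not lie beyond the scatter. The estimate for compound 4 is 20000 nM, with a range from 7000 nM to 60000 nM.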

Compound 4, half-maximal inhibitory concentration: > 20000 nM
Compound 4 ended at the assay's limit; the forecaster's own chance of this, stated with the estimate: 65%; the middle value sits exactly at the limit.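

In this assay compound 4 gives > 20000 nM, which is a limit and not a number. Compound 3 gives > 20000 nM, also a limit, so the step between these two compounds cannot be read. The compounds shown leave open what the true values of compound 3 and compound 4 are, and whether exchanging 3,4-dimethoxybenzyl for 4-nitrophenyl changes the activity at all.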